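This account rests on a few compounds, and the source may have more. Where it says the series, first, only, none or still open, it means among the compounds named here.

Working notes on the series in a physicochemical assay for lipophilicity, read by HPLC, tested at 5 mM; on this read-out lower numbers stand for lower lipophilicity and higher numbers for higher lipophilicity. Two compounds carry numbers. Compound 1 `CC(Oc1ccc(Oc2ccc(C(F)(F)F)cc2)cc1)C(=O)Cn1nnc(-c2ccc(Cl)cc2)n1` gives 7 in this assay. Compound 2 `CCCCCCCCc1ccc(OC(C)C(=O)Cn2nnc(-c3ccc(C(=O)O)cc3)n2)cc1` gives 5.9 in this assay, the lowest of the two numbers; its nearest neighbour is compound 1, which lies higher by an amount beyond the scatter. Going by the values given here, no two measured compounds differ in a single place, so no measured step exists to lean on.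

Compound 3 `CC(Oc1ccc(Oc2ccc(C(F)(F)F)cc2)cc1)C(=O)Cn1nnc(-c2ccc(C(=O)O)cc2)n1` awaits measurement. Relative to compound 2 it carries 4-(trifluoromethyl)phenoxy in place of octyl on an aromatic carbon. The entering group is also present in compound 1, though compound 1 differs from compound 3 elsewhere as well, so the value of compound 1, 7, offers only loose guidance. The step of a number 0.30 log units lower from compound 2 to compound 3 (within the scatter) is expected to be small, leaning slightly downward, and probably not beyond the scatter. Compound 3 is estimated at 5.6, with a range from 4.9 to 6.4.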

Compound 3, partition coefficient: 3.5
Beside the measured number, compound 3's estimate is 2.10 log units above it, and the stated range ends above it.
By their numbers in this assay, from the lowest: compound 3; then compound 2; then compound 1.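

In this assay the position para to a large group now has a measured step: 4-(trifluoromethyl)phenoxy in place of octyl on an aromatic carbon gives a number 2.40 log units lower from compound 2 to compound 3 (beyond the scatter) and the exchange is therefore not neutral for this read-out. A second place also shows a large step, with carboxy in place of chloro on an aromatic carbon giving a number 3.50 log units lower from compound 1 to compound 3 (beyond the scatter) on the same 4-(trifluoromethyl)phenoxy background. No measurement on hand accounts for either step.

Going by these compounds, what a shorter alkyl chain or a methoxy group would give in place of octyl, and what an amine or a nitrile would give in place of carboxy, stays open. So does whether either step holds on a compound joining octyl with chloro.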